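Replacing the 2-nitrophenyl group of compound 1

The source may hold more compounds than are shown below. What is called first, only, known or untested is meant among the compounds shown, and "the series" means these compounds.

Within the data shown here, in a functional assay on HCT-116 cells (Homo sapiens) for inhibition, read by MTT assay, with a stated time of 72 h (a lower number here means a stronger inhibitor, a higher number a weaker inhibitor), compound 1 `CC1=NN(c2ccccc2)C(=O)[C@]12C(=O)C=CC[C@H]2c1ccccc1[N+](=O)[O-]` gives 11200 nM, the lower of the two numbers so far. Its mirror image, compound 2 `CC1=NN(c2ccccc2)C(=O)[C@@]12C(=O)C=CC[C@@H]2c1ccccc1[N+](=O)[O-]`, gives 66800 nM. The measured step is a 6.0-fold higher number from compound 1 to compound 2 (0.78 log units; beyond the scatter), and it arises because of the fact that compounds 1 and 2 differ only in the configuration as drawn.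

Compound 3 `CC1=NN(c2ccccc2)C(=O)[C@]12C(=O)C=CC[C@H]2c1ccc(C)cc1` keeps the configuration drawn for compound 1 but carries 4-methylphenyl in place of 2-nitrophenyl on a saturated ring carbon. Among the measured compounds shown here, the one measured step concerns configuration alone, and no measured step exchanges this group. The expectation therefore starts from compound 1 at 11200 nM, and no step beyond the scatter is expected in this assay, in either direction, though the margin is wide. The estimated step is a 1.3-fold higher number from compound 1 to compound 3 (0.10 log units; within the scatter). For compound 3 the expected value is 14000 nM, with an estimated range from 4500 nM to 45000 nM.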

Compound 3, half-maximal inhibitory concentration: 4220 nM
Estimate against measurement, compound 3: 3.3-fold (0.52 log units) above; the whole stated range lies above it.
By their numbers in this assay, from the lowest: compound 3; then compound 1; then compound 2.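

In this assay, the exchange of 2-nitrophenyl for 4-methylphenyl on the saturated ring carbon gives a 2.7-fold lower number from compound 1 to compound 3 (0.42 log units; beyond the scatter), so this position responds to the group it carries as well as to the configuration. Among these compounds, the entering group has no hydrogen-bond acceptors, where 2-nitrophenyl has two, and compound 3 still reaches the lowest number so far, so those acceptors are not required for a number at this level. Nothing on hand accounts for the direction or size of this step.

The compounds shown leave open whether the configuration step, a 6.0-fold higher number from compound 1 to compound 2 (0.78 log units; beyond the scatter), carries over to 4-methylphenyl. They also leave open how this position would respond to a phenyl ring bearing an amine, a carboxylic acid or a longer chain such as butyl.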